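A few compounds are considered here, and "the series" means these few. Any claim that something is new, unique, unknown or untested is made for them only; others in the source may bear on it.

Compound 1 `COc1ccc(-n2c(S)nnc2-c2cc(OC)c(OC)c(OC)c2)cc1`: > 60000 nM
Compound 2 `COc1ccc(-n2c(SCC(=O)c3ccc4ccccc4c3)nnc2-c2cc(OC)c(OC)c(OC)c2)cc1`: > 60000 nM
Compound 3 `COc1cc(-c2nnc(S)n2-c2ccc(N(C)C)cc2)cc(OC)c1OC`: > 60000 nM

Every entry above, measured in a functional assay on HCT-116 cells (Homo sapiens) for inhibition, read by MTT assay, with a stated time of 48 h (a lower number here means a stronger inhibitor, a higher number a weaker inhibitor), is a limit of the assay and not a number. Compound 3 stands at a limit, > 60000 nM. The same holds for the whole set, which rests on (the limit of > 60000 nM in this assay, at which 3 of the 3 values shown sit), so no rank can be given to compound 3.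

Compound 4 `COc1cc(-c2nnc(SCc3ccc(C)cc3)n2-c2ccc(N(C)C)cc2)cc(OC)c1OC` differs from compound 3 in one place: 4-methylbenzyl in place of hydrogen on a sulfur. Among the compounds with values here, the only measured step between neighbours, a step that the two limits leave unreadable from compound 1 to compound 3, concerns a different place and offers no size to carry over. Compound 2 also carries a group on its sulfur, and it too gives only a limit, > 60000 nM. Within the data shown here, no measured step therefore sizes the change from hydrogen to 4-methylbenzyl, and the expectation in this assay is a cautious one. Compound 3 is held at a limit, > 60000 nM, so any number reported for compound 4 would mark a stronger inhibitor, and it may well stay at the limit. The expected change is an at least 2.1-fold lower number from compound 3 to compound 4 (0.33 log units; beyond the scatter). For compound 4 the estimated value is 28000 nM, with an expected range from 5000 nM to 60000 nM.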

Compound 4, half-maximal inhibitory concentration: > 60000 nM
Compound 4: no number, only a limit; the forecaster's own chance of this, stated with the estimate: 50%; middle value at least 2.1-fold (0.33 log units) from the limit.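

In this assay compound 4 gives > 60000 nM, which is a limit of the assay and not a number. Within the data shown here, compound 3 also stands at a limit, so no step between compound 3 and compound 4 can be read, and the set still rests on a single limit: the limit of > 60000 nM in this assay, at which 4 of the 4 values shown sit. The compounds shown leave open which change to the shared core, if any, would give a readable value in this assay.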